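This account rests on a few compounds, and the source may have more. Where it says the series, first, only, none or still open, it means among the compounds named here.

Measured so far in a functional assay on BJAB cells (Homo sapiens) for antiproliferative activity, with a stated time of 4 days; a higher number here means that more compound is needed for the effect, a lower number that less compound is needed:
compound 1 `Cc1nn(-c2nc(-c3ccc(Cl)c(Cl)c3)c(SC(C)C)s2)c(C(=O)O)c1-c1cncnc1` gives 22000 nM
compound 2 `CNc1cc(-c2c(C)nn(-c3nc(-c4ccc(Cl)c(Cl)c4)c(SC(C)C)s3)c2C(=O)O)ccn1` gives 18000 nM

Compound 2 holds the lowest of the two numbers, but its gap to compound 1 is small: a 1.2-fold lower number from compound 1 to compound 2 (0.09 log units; within the scatter). That step, swapping one six-membered aromatic ring for another at the same place, is the only one on record and stayed within the scatter.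

Compound 3 `Cc1nn(-c2nc(-c3ccc(Cl)c(Cl)c3)c(SC(C)C)s2)c(C(=O)O)c1-c1ccccc1Cl` differs from compound 2 in the same place: 2-chlorophenyl in place of 2-(methylamino)pyridin-4-yl on an aromatic carbon. Going by the values given here, with the one comparable step showing no movement, no step beyond the scatter is expected in this assay, a 1.1-fold higher number from compound 2 to compound 3 (0.05 log units; within the scatter). Compound 3 is estimated at 20000 nM, range 7000 nM to 55000 nM.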

Compound 3, half-maximal effective concentration: 13100 nM
Beside the measured number, compound 3's estimate is 1.5-fold (0.18 log units) above it; the range from low to high includes it.
By their numbers in this assay, from the lowest: compounds 3, 2 and 1 (each within the scatter of the next).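

In this assay, this place on the five-membered aromatic ring with 2 nitrogen now also carries a six-membered aromatic ring of carbon only, and both a 1.4-fold lower number from compound 2 to compound 3 (0.14 log units; within the scatter) and a 1.7-fold lower number from compound 1 to compound 3 (0.23 log units; within the scatter) stay within the scatter. Exchanging 2-(methylamino)pyridin-4-yl, with its hydrogen-bond donor and acceptors, for 2-chlorophenyl, with none, therefore produces no readable change here. No available evidence bears on this result.

All three compounds carry a six-membered aromatic ring at this place. From the compounds shown here alone, whether a morpholine, a primary amine or a longer alkyl chain there would give a step beyond the scatter remains open.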